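Removing the substituted phenol: what compound 4 may show

The source may report more compounds than this note shows. Statements on the series, on what has been measured and on what is new or still open speak of the compounds shown alone.

Compound 1 `CN(C)CCn1cnnc1-c1cc(Oc2ccc(NC(=O)N/N=C/c3ccc(O)c(F)c3)cc2F)ccn1`: 2620 nM
Compound 2 `CN(C)CCn1cnnc1-c1cc(Oc2ccc(NC(=O)N/N=C/c3cc(Br)c(O)c(Br)c3)cc2F)ccn1`: 3760 nM
Compound 3 `Cn1cnnc1-c1cc(Oc2ccc(NC(=O)N/N=C/c3ccccc3)cc2F)ccn1`: 15700 nM

In a functional assay on NCI-H460 cells (Homo sapiens) for cytotoxicity, read by MTT assay, with a stated time of 72 h (a lower number here means a stronger inhibitor, a higher number a weaker inhibitor), compound 2 holds the second highest of the three numbers; compound 1 sits closest to it, with a 1.4-fold higher number from compound 1 to compound 2 (0.16 log units; within the scatter), while compound 3 lies furthest away. Compound 4 `CN(C)CCn1cnnc1-c1cc(Oc2ccc(NC(=O)N/N=C/c3ccccc3)cc2F)ccn1` differs from compound 2 by phenyl in place of 3,5-dibromo-4-hydroxyphenyl on a carbon with a double bond to nitrogen. For the measured compounds named here, only one measured step touches this carbon, and it is small: a 1.4-fold higher number from compound 1 to compound 2 (0.16 log units; within the scatter). Compound 3 also carries a phenyl at this place but has a different group on the shared core, so its value can only hint. Because compound 3 gives 15700 nM, compound 4 is expected to land somewhat weaker than compound 2, an expected 2.1-fold higher number from compound 2 to compound 4 (0.33 log units; beyond the scatter), with compound 4 estimated at 8000 nM, between 3000 nM and 20000 nM.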

Compound 4, half-maximal inhibitory concentration: 1780 nM
Estimate against measurement, compound 4: 4.5-fold (0.65 log units) above, outside the stated range (below it).
By their numbers in this assay, from the lowest: compounds 4, 1 and 2 (each within the scatter of the next, the first and the last beyond it); then compound 3.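

In this assay, the substituted phenols at this carbon offer no gain over plain phenyl: the change gives a 2.1-fold lower number from compound 2 to compound 4 (0.32 log units; beyond the scatter) and a 1.5-fold lower number from compound 1 to compound 4 (0.17 log units; within the scatter). The larger shift lies elsewhere, as adding (dimethylamino)methyl in place of hydrogen on the saturated chain carbon gives an 8.8-fold lower number from compound 3 to compound 4 (0.95 log units; beyond the scatter), so the phenyl of compound 3 does not account for its high number. No measurement here explains these steps. Still open, going by these compounds, is how an amine or a carboxylic acid on this phenyl would read. A longer chain carrying the dimethylamino group also remains untested among the compounds shown.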